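Replacing 3-fluorophenyl with 3,4-dimethylphenyl

The source may hold more compounds than are shown below. What is called first, only, known or untested is meant among the compounds shown, and "the series" means these compounds.

For the measured compounds named here, in a toxicity assay on HUVEC cells (Homo sapiens) for inhibition (a lower number here means a stronger inhibitor of growth, a higher number a weaker inhibitor of growth), compound 3 `Cc1nc(-c2ccccc2)c(C(=O)N2CCN(c3cccc(F)c3)CC2)o1` gives 1.05 ug/mL, the highest of the three numbers so far. Compound 1 `Cc1nc(-c2ccccc2)c(C(=O)N2CCN(c3cccc(C)c3C)CC2)o1` gives 0.38 ug/mL and compound 2 `Cc1cc(C)cc(N2CCN(C(=O)c3oc(C)nc3-c3ccccc3)CC2)c1` gives 0.356 ug/mL, two values within the scatter of each other. Compound 4 `Cc1nc(-c2ccccc2)c(C(=O)N2CCN(c3ccc(C)c(C)c3)CC2)o1` carries 3,4-dimethylphenyl in place of 3-fluorophenyl on an amine nitrogen in a ring. Compound 1 and compound 2 bear other dimethylphenyl groups, so two steps apply: a 2.8-fold higher number from compound 1 to compound 3 (0.44 log units; beyond the scatter) and a 2.9-fold higher number from compound 2 to compound 3 (0.47 log units; beyond the scatter), both modest and beyond the scatter. Run in reverse, they point to a lower number. The expected change is a 2.8-fold lower number from compound 3 to compound 4 (0.45 log units; beyond the scatter), of similar size. Compound 4 is estimated at 0.37 ug/mL, with an expected range from 0.18 ug/mL to 0.75 ug/mL in this assay.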

Compound 4, concentration for 50% growth inhibition: 3.52 ug/mL
Beside the measured number, compound 4's estimate is 9.5-fold (0.98 log units) below it; measured number above the stated range.
By their numbers in this assay, from the lowest: compounds 2 and 1 (each within the scatter of the next); then compound 3; then compound 4.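

In this assay, the dimethylphenyl groups at this place do not act alike: the data show a 9.3-fold higher number from compound 1 to compound 4 (0.97 log units; beyond the scatter) and a 9.9-fold higher number from compound 2 to compound 4 (1.00 log units; beyond the scatter). The 3,4-dimethylphenyl group also stands apart from 3-fluorophenyl, with a 3.4-fold higher number from compound 3 to compound 4 (0.53 log units; beyond the scatter), so among these compounds, carrying two methyl groups does not by itself give the lower number. Nothing available explains why this dimethylphenyl group differs from the other two. As far as these compounds go, it remains open where a phenyl group with a single methyl, or one with a methoxy group, would fall at this place.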